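A few compounds are considered here, and "the series" means these few. Any claim that something is new, unique, unknown or untested is made for them only; others in the source may bear on it.

Measured so far:
compound 1, `C[C@@H](NC(=O)c1ccc(C#Cc2ccc(F)cc2)cn1)C(C)(C)O` — 66.2%
compound 2, `C[C@@H](NC(=O)c1ccc(C#Cc2cc(F)cc(F)c2)cn1)C(C)(C)O` — 61.6%
compound 3, `C[C@@H](NC(=O)c1ccc(C#Cc2ccc(F)cc2F)cn1)C(C)(C)O` — 61.2%

The account follows the step from compound 3 to compound 4. In a functional assay on HEK293 cells for positive allosteric modulation of metabotropic glutamate receptor 5 (Rattus norvegicus), read by fluorescence and calcium flux (a lower number here means a smaller maximal response, a higher number a larger maximal response), compound 3 gives 61.2%, which places it at the low end of the three numbers, yet neither gap separates it from the others beyond the scatter: a number 0.4 percentage points lower from compound 2 to compound 3 (within the scatter) and a number 5 percentage points lower from compound 1 to compound 3 (within the scatter).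

Compound 4, `Cc1ccc(C#Cc2ccc(C(=O)N[C@H](C)C(C)(C)O)nc2)cc1`, has not yet been measured. It differs from compound 3 in one place: 4-methylphenyl in place of 2,4-difluorophenyl on a triple-bonded carbon. Within the data shown here, two measured steps bear on this kind of change, both exchanges of the aryl group on the triple-bonded carbon: a number 4.6 percentage points lower from compound 1 to compound 2 (within the scatter) and a number 0.4 percentage points lower from compound 2 to compound 3 (within the scatter). Each stayed within the scatter, so swapping one fluorinated aryl for another has left the maximal response essentially unchanged across compounds 1, 2 and 3. The move to 4-methylphenyl removes both fluorines and brings a methyl group, which none of the three measured compounds covers, so the expectation rests on the steadiness of the series rather than a direct precedent. Compound 4 is therefore expected to show a step of a number 1.8 percentage points higher from compound 3 to compound 4 (within the scatter), that is, none beyond the scatter. The estimate for compound 4 is 63%, with a range from 50% to 76%.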

Compound 4, largest response reached (reported as efficacy), in percent of the reference or control that the assay uses: 63.1%
Beside the measured number, compound 4's estimate is 0.1 percentage points below it, and the stated range covers the measured number.
By their numbers in this assay, from the lowest: compounds 3, 2, 4 and 1 (each within the scatter of the next).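

In this assay, the aryl group on the triple-bonded carbon now extends beyond fluorinated phenyl rings to one with no fluorine at all, and 4-methylphenyl stands within the scatter of both difluorophenyl groups (a number 1.9 percentage points higher from compound 3 to compound 4 (within the scatter); a number 1.5 percentage points higher from compound 2 to compound 4 (within the scatter)). Among these compounds, the direct exchange of methyl for fluoro on an aromatic carbon, which the earlier compounds did not cover, also stays within the scatter (a number 3.1 percentage points lower from compound 1 to compound 4 (within the scatter)), so across compounds 1 to 4 neither the fluorine count nor the methyl group separates one compound from another in maximal response. Nothing available explains why these four aryl groups read alike, and no supporting data bear on this result.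

It remains open whether this steadiness would hold for a phenyl ring carrying a methoxy, a nitrile, an amine or a carboxylic acid, or for a longer chain in place of the methyl group, since all four groups shown are six-membered aromatic rings of carbon only with fluoro or methyl on them. The core and the amide side chain are also the same in all four compounds, so how much either contributes to the maximal response cannot be told from them.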